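A Chlorophenyl Swap at a Flat Baseline

This account rests on a few compounds, and the source may have more. Where it says the series, first, only, none or still open, it means among the compounds named here.

Compound 1, `Cn1c(=O)n(Cc2ccccc2C#N)c2c(N3CCC[C@@H](N)C3)ncnc21`: in an assay on isolated protein for inhibition of Dipeptidyl peptidase 9 (Homo sapiens), read by luminescence, with a stated time of 15 min (a lower number here means a stronger inhibitor, a higher number a weaker inhibitor), compound 1 gives > 100000 nM, a limit of the assay.
Compound 2, `Cn1c(=O)n(Cc2cccc(C#N)c2)c2c(N3CCC[C@@H](N)C3)ccnc21`: in this assay compound 2 gives > 100000 nM, a limit of the assay.
Compound 3, `Cn1c(=O)n(Cc2ccc(C#N)cc2)c2c(N3CCC[C@@H](N)C3)ccnc21`: in this assay compound 3 gives > 100000 nM, a limit of the assay.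

Compound 3 stands where every measured compound stands, at the limit of this assay: none of the three returns a number, and the limit of > 100000 nM in this assay, at which 3 of the 3 values shown sit, is the whole of the evidence. For the measured compounds named here, the one step between neighbours, a step that the two limits leave unreadable from compound 2 to compound 3, is likewise unreadable. Compound 4, `Cn1c(=O)n(Cc2ccccc2Cl)c2c(N3CCC[C@@H](N)C3)ccnc21`, differs from compound 3 by 2-chlorophenyl in place of 4-cyanophenyl on a saturated chain carbon bound to an aromatic nitrogen. Going by the values given here, no measured step bears on this change, and the only step that touches the same position gave no readable size, so there is no ground in these data to expect a measurable number. The expectation for compound 4 is a step that the limit leaves unreadable from compound 3 to compound 4, ending again at the limit in all likelihood. Compound 4 is estimated at 150000 nM, with a range from 30000 nM to 1000000 nM.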

Compound 4, half-maximal inhibitory concentration: > 100000 nM
Compound 4 ended at the assay's limit; the forecaster's own chance of this, stated with the estimate: 85%; the middle value does not contradict the limit.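

Compound 4 also gives no number, so the steps to it from compound 2 and from compound 3 cannot be read: the limit of > 100000 nM in this assay, at which 4 of the 4 values shown sit.

The compounds shown leave open how the cyanobenzyl and 2-chlorobenzyl groups truly compare, and whether any of these four compounds would give a number in this assay.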